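A few compounds are considered here, and "the series" means these few. Any claim that something is new, unique, unknown or untested is made for them only; others in the source may bear on it.

Compounds measured in a functional assay on cells for antagonist activity at C-X-C chemokine receptor type 4 (Homo sapiens), read by fluorescence and calcium flux, with stated times of 25 min and 90 s; a higher number here means a weaker inhibitor, a lower number a stronger inhibitor:
- compound 1, `c1cncc(CNCCCCN(C[C@H]2Cc3ccccc3CN2)[C@H]2CCCc3cccnc32)c1`: 15.3 nM
- compound 2, `c1ccc2c(c1)CN[C@@H](CN(CCCCNC1CCSCC1)[C@H]1CCCc3cccnc31)C2`: 54.7 nM
- compound 3, `CC(C)(CCN)CN(C[C@H]1Cc2ccccc2CN1)[C@H]1CCCc2cccnc21`: only the assay limit > 33300 nM

Compound 3 therefore stands at the limit of this assay, not at a number; this is the case the limit of > 33300 nM in this assay, at which 1 of the 3 values shown sits, describes. The shared core is kept throughout; the series varies only the group on a saturated chain carbon bound to an amine nitrogen. Compound 4, `C(=C/CN(C[C@H]1Cc2ccccc2CN1)[C@H]1CCCc2cccnc21)\CNC1CCOCC1`, is not yet measured. It differs from compound 3 by a group of 10 heavy atoms (8 carbon, 1 nitrogen, 1 oxygen; one six-membered non-aromatic ring with 1 hetero atom) in place of a group of 6 heavy atoms (5 carbon, 1 nitrogen; no ring), on a saturated chain carbon bound to an amine nitrogen.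

Within the data shown here, two measured steps bear on this change, both in the opposite direction: an at least 2100-fold higher number from compound 1 to compound 3 (3.33 log units; beyond the scatter) and an at least 600-fold higher number from compound 2 to compound 3 (2.78 log units; beyond the scatter). In each, exchanging a ring-bearing group for the acyclic six-heavy-atom group moved the number up to the assay limit. Compound 4 restores a six-membered ring with one heteroatom, as in compound 1 and compound 2, so a large downward step is expected from compound 3 to compound 4, an at least 330-fold lower number from compound 3 to compound 4 (2.52 log units; beyond the scatter), from a limit to a measurable number. Compound 4 is expected to give about 100 nM in this assay, within 15 nM to 1500 nM.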

Compound 4, half-maximal inhibitory concentration: 15.5 nM
Compound 4: the middle estimate sits 6.5-fold (0.81 log units) above what was measured, within the range that was stated.
By their numbers in this assay, from the lowest: compounds 1 and 4 (each within the scatter of the next); then compound 2. At a limit, above all of these: compound 3.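

At this position in this assay, a ring-bearing group of a further kind, 3-((oxan-4-yl)amino)prop-1-en-1-yl, again gives a measurable number: an at least 2100-fold lower number from compound 3 to compound 4 (3.33 log units; beyond the scatter). The reading for compound 3 is a limit and not a number: the limit of > 33300 nM in this assay, at which 1 of the 4 values shown sits. With the aromatic ring gone from this group, the value holds against the (pyridin-3-yl)methyl-bearing group, a 1.0-fold higher number from compound 1 to compound 4 (0.01 log units; within the scatter), and the thian-4-yl-bearing group is separated from the new group, a 3.5-fold lower number from compound 2 to compound 4 (0.55 log units; beyond the scatter).

Compound 2 and compound 4 differ in both the ring heteroatom and the double bond, so the compounds shown cannot assign that gap to either one. Also open, from the compounds shown here alone, is how a longer chain, or a carboxylic acid in place of the ring-bearing amine, would read at this position.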